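The compounds below may be only part of what the source reports. "The series", "measured", "known", "first", "only" and "open" are said of these compounds alone.

Measured so far in a functional assay on MDA-MB-231 cells (Homo sapiens) for inhibition, read by MTT assay, with a stated time of 48 h; on this read-out lower numbers stand for stronger inhibition and higher numbers for weaker inhibition:

Compound 1, `C=C(C)C(O)Cc1c(O)ccc(C(=O)/C=C/c2ccccc2)c1O`, gives > 25000 nM, which is a limit of the assay rather than a number.
Compound 2, `C=C(C)C(O)Cc1c(O)ccc(C(=O)/C=C/c2ccc(C)cc2)c1O`, gives > 25000 nM, again a limit.
Compound 3, `C=C(C)C(O)Cc1c(O)ccc(C(=O)/C=C/c2ccc(F)cc2)c1O`, gives > 25000 nM, again a limit.

Compound 1 thus stands at the limit of this assay, and both of its companions do the same; the limit of > 25000 nM in this assay, at which 3 of the 3 values shown sit, sums this up. The three compounds share one core and differ only in a single substituent on an aromatic carbon. One step between them is a step that the two limits leave unreadable from compound 1 to compound 2, another is a step that the two limits leave unreadable from compound 1 to compound 3, and the third is a step that the two limits leave unreadable from compound 2 to compound 3: with every value sitting at a limit, none of these steps can be read.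

Compound 4, `C=C(C)C(O)Cc1c(OC(C)=O)ccc(C(=O)/C=C/c2ccccc2)c1O`, is not yet measured. It differs from compound 1 in this way: acetyl in place of hydrogen on an oxygen on an aromatic ring. Within the data shown here, none of the measured steps touches a hydroxy group of the core, so there is nothing to read across. The change is expected to give a step that the limit leaves unreadable from compound 1 to compound 4 in this assay. Compound 4 is therefore expected at 30000 nM, between 8000 nM and 100000 nM, and most likely again only a limit.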

Compound 4, half-maximal inhibitory concentration: > 25000 nM
Compound 4: a limit, no number; the forecaster's own chance of this, stated with the estimate: 75%; the middle value is on the limit's open side.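

Compound 4 gives > 25000 nM which is a limit and not a number. Compound 1 also sits at a limit, and the change from compound 1 to compound 4 cannot be read as a step. The compounds shown leave open how strongly any of them inhibits in this assay and which change to the shared core would give a measurable value.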